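The compounds below may be only part of what the source reports. "The series", "measured", "known", "first", "only" and "open" are said of these compounds alone.

Measured so far:
- compound 1, `CNCCNc1nnc(-c2ccccc2)cc1C`: 2 mg/kg
- compound 2, `Cc1cc(-c2ccccc2)nnc1NCCN(C)C`: 10 mg/kg

Compound 2 stands as the higher of the two numbers in a functional assay on the whole organism with Mus musculus as the target; a lower number here means that less compound is needed, a higher number that more compound is needed for the effect; its nearest neighbour is compound 1, which gave 2 mg/kg. Within the data shown here, the one measured step, a 5.0-fold higher number from compound 1 to compound 2 (0.70 log units; beyond the scatter), arose from a methyl in place of hydrogen on an amine nitrogen, and it pushed the number up beyond the scatter.

Compound 3, `Cc1cc(-c2ccccc2)nnc1NC(C)CN`, is not yet measured in this assay. It differs from compound 2 by 1-(aminomethyl)ethyl in place of 2-(dimethylamino)ethyl on a nitrogen on an aromatic ring. Among the measured compounds shown here, the entering group carries a hydrogen-bond donor on its nitrogen, where the leaving group carried none, so the change runs in the opposite sense to the one step already seen: compound 1, with hydrogen on the amine nitrogen, gave the lower number, and compound 2, with methyl there, the higher. For the measured compounds named here, on that basis compound 3 is expected to show a step of a 3.3-fold lower number from compound 2 to compound 3 (0.52 log units; beyond the scatter), back toward the number of compound 1; the branching of the chain is a change for which no step is available. The estimate for compound 3 in this assay is 3 mg/kg, with a range from 1 mg/kg to 10 mg/kg.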

Compound 3, minimum effective dose: 2 mg/kg
The estimate for compound 3 lay 1.5-fold (0.18 log units) above the measured number, and the stated range covers the measured number.
By their numbers in this assay, from the lowest: compounds 1 and 3 (each within the scatter of the next); then compound 2.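

In this assay, the position on the nitrogen on an aromatic ring accepted a change of the whole chain and not only of its amine end: 1-(aminomethyl)ethyl in place of 2-(dimethylamino)ethyl gave a 5.0-fold lower number from compound 2 to compound 3 (0.70 log units; beyond the scatter). Set against the 2-(methylamino)ethyl chain, the same group gave no change at the digits printed from compound 1 to compound 3 (within the scatter), so the two chains with hydrogen on the amine nitrogen stand together, compound 2 stands apart from both, and the branched chain brought no difference that these numbers can resolve. Nothing measured on these compounds offers an explanation for this pattern.

Branching and the substitution at the amine end change together in compound 3, so their separate contributions remain open, and an unbranched 2-aminoethyl chain would help to separate them. On these data alone, it also remains open whether the pattern extends to a longer chain such as 3-aminopropyl or to a cyclic amine such as piperidine on the same nitrogen.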